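A few compounds are considered here, and "the series" means these few. Any claim that something is new, unique, unknown or untested is made for them only; others in the source may bear on it.

Working notes, series of substituted two-ring amides tested in an assay on isolated protein for inhibition of DNA topoisomerase 1 (Homo sapiens), with a stated time of 30 min, tested at 100 uM; a lower number here means a weaker effect, a higher number a stronger effect of the compound at the concentration tested.

Measured so far:
- compound 1 `Cc1ccc2c(=O)[nH]c(-c3ccccc3C)nc2c1`: 100%
- compound 2 `Cc1ccc2c(=O)[nH]c(-c3cccc(F)c3)nc2c1`: 77.5%

Compound 2 stands at the lower of the two numbers in this assay; the nearest number is that of compound 1, which lies higher by an amount beyond the usual scatter. Among the measured compounds shown here, the two compounds differ in more than one place, so the pair gives no single step, and only the two values themselves can be read.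

The next compound, compound 3 `Cc1ccc2c(=O)[nH]c(-c3cccc(C(F)(F)F)c3)nc2c1`, differs from compound 2 in one place:

trifluoromethyl in place of fluoro on an aromatic carbon

For the measured compounds named here, no measured pair shows what a trifluoromethyl in place of a fluoro does in this assay, so the step from compound 2 to compound 3 has no precedent to lean on. The expectation is a step of a number 2.5 percentage points lower from compound 2 to compound 3 (within the scatter), with no direction beyond the scatter and wide uncertainty on either side. On that basis compound 3 is estimated at 75% in this assay, with a range from 45% to 100%.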

Compound 3, a percentage reported as inhibition, at one concentration (the size of the read-out at that concentration, not a potency): 100%
Compound 3: the middle estimate sits 25 percentage points below what was measured; low and high end bracket the measured number.
By their numbers in this assay, from the lowest: compound 2; then compounds 1 and 3 (each within the scatter of the next).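

In this assay, among the compounds shown here, the change from fluoro to trifluoromethyl on this aromatic carbon, meta to a large group, gives a number 22.5 percentage points higher from compound 2 to compound 3 (beyond the scatter), the first step that can be read, and it shows that the read-out at this position depends on which group sits there. The step comes with a move from 1 heavy atom to 4 heavy atoms, while the hydrogen-bond donor and acceptor counts stay at 0 and neither group carries a net charge, so it appears without any change in those counts. Nothing at hand explains the size of this step or ties it to a particular property of either group.

Going by these compounds, it remains open whether a chlorine, a methoxy, an amine or a carboxylic acid on the same carbon would fall nearer to compound 2 or compound 3, and whether the same exchange of fluoro for trifluoromethyl would give a similar step elsewhere on the ring. Compound 3 gives 100% at a single concentration, so this number shows the size of the read-out at that concentration and leaves its potency unknown.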